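Dimethylamino for Pyrrolidinyl on the Side Chain of Compound 1

The compounds below may be only part of what the source reports. "The series", "measured", "known", "first", "only" and "open" are said of these compounds alone.

Compound 1 `O=C(Nc1ccc(C(=O)N2CCCN(CCN3CCCC3)c3sccc32)cc1)c1ccccc1-c1ccccc1` is the weaker of the two compounds measured in an assay on CHO cells for inhibition of Vasopressin V2 receptor (Homo sapiens), read by radioligand binding (a higher number here means a weaker inhibitor, a lower number a stronger inhibitor), where compound 1 gives 200 nM. In this assay, going by the values given here, compound 2 `CN1CCN(CCCCOc2cc(C(=O)N3CCCCc4sccc43)ccc2NC(=O)c2ccccc2-c2ccccc2)CC1` gives 1 nM; these two compounds differ in several places, so no single step connects them. Compound 3 `CN(C)CCN1CCCN(C(=O)c2ccc(NC(=O)c3ccccc3-c3ccccc3)cc2)c2ccsc21` differs from compound 1 in one place: dimethylamino in place of pyrrolidin-1-yl on a saturated chain carbon, two bonds along the chain from a nitrogen on an aromatic ring in a ring. Among the compounds with values here, no measured pair isolates such a change, so only a modest step, in either direction, is expected for a 1.5-fold higher number from compound 1 to compound 3 (0.18 log units; within the scatter). Compound 3 is accordingly estimated at 300 nM, with a range from 100 nM to 900 nM.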

Compound 3, half-maximal inhibitory concentration: 80 nM
The estimate for compound 3 lay 3.8-fold (0.57 log units) above the measured number; the whole stated range lies above it.
By their numbers in this assay, from the lowest: compound 2; then compound 3; then compound 1.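

In this assay, the change from 2-(pyrrolidin-1-yl)ethyl to 2-(dimethylamino)ethyl gives a 2.5-fold lower number from compound 1 to compound 3 (0.40 log units; beyond the scatter). This only single-place step among the compounds shows that the amine at the end of this side chain affects the number, and that the ring of pyrrolidin-1-yl is not required for inhibition here. No available evidence accounts for the step. From the compounds shown here alone, how other amines at this position, such as piperidin-1-yl, morpholin-4-yl or a primary amine, would compare remains open. So does the effect of a longer chain carrying dimethylamino.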